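Amide-nitrogen substituents in an EP1 binding series

This account rests on a few compounds, and the source may have more. Where it says the series, first, only, none or still open, it means among the compounds named here.

Measured compounds, all tested in an assay on CHO-K1 cells for displacement of a labelled ligand from prostaglandin E2 receptor EP1 subtype (Homo sapiens); on this read-out lower numbers stand for stronger inhibition and higher numbers for weaker inhibition:
Compound 1 `Cc1cc(C(N)=O)nn1Cc1cc(Cl)ccc1OCc1ccccc1` gives 126 nM.
Compound 2 `Cc1cc(C(=O)Nc2cccc(F)c2)nn1Cc1cc(Cl)ccc1OCc1ccccc1` gives 200 nM.
Compound 3 `Cc1cc(C(=O)NCc2ccccc2)nn1Cc1cc(Cl)ccc1OCc1ccccc1` gives 39.8 nM.

Compound 1 carries the unsubstituted amide and stands second highest of the three numbers. Its nearest neighbour is compound 2, with a 1.6-fold higher number from compound 1 to compound 2 (0.20 log units; within the scatter). The furthest is compound 3, with a 3.2-fold lower number from compound 1 to compound 3 (0.50 log units; beyond the scatter). Between the two substituted amides the step is a 5.0-fold lower number from compound 2 to compound 3 (0.70 log units; beyond the scatter).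

Compound 4 `Cc1cc(C(=O)NCc2ccccn2)nn1Cc1cc(Cl)ccc1OCc1ccccc1` is not yet measured. It differs from compound 1 in one place: (pyridin-2-yl)methyl in place of hydrogen on an amide-type nitrogen.

Going by the values given here, the step that bears most on this change is the one from compound 1 to compound 3, where a benzyl group entered on the same amide-type nitrogen and gave a modest lowering beyond the scatter. Among the compounds with values here, the (pyridin-2-yl)methyl group of compound 4 is likewise a six-membered aromatic ring joined through one carbon to the amide nitrogen, so a lowering of similar size is expected, with the single aryl substituent of compound 2 as the only counter-example, which moved the number the other way within the scatter. In this assay the step for compound 4 is therefore expected to be a 2.5-fold lower number from compound 1 to compound 4 (0.40 log units; beyond the scatter).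

The estimate for compound 4 in this assay is 50 nM, with an expected range from 20 nM to 130 nM.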

Compound 4, half-maximal inhibitory concentration: 25.1 nM
For compound 4 the middle estimate is 2.0-fold (0.30 log units) above the measured one; low and high end bracket the measured number.
By their numbers in this assay, from the lowest: compounds 4 and 3 (each within the scatter of the next); then compounds 1 and 2 (each within the scatter of the next).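

In this assay, the gain from a one-carbon-linked aromatic ring on the amide-type nitrogen is not confined to benzyl, since (pyridin-2-yl)methyl in place of hydrogen also lowers the number (a 5.0-fold lower number from compound 1 to compound 4 (0.70 log units; beyond the scatter)). At this position, the ring nitrogen makes no difference that can be read: pyridin-2-yl in place of phenyl on the saturated chain carbon stays within the scatter (a 1.6-fold lower number from compound 3 to compound 4 (0.20 log units; within the scatter)), so compound 3 and compound 4 stand level. Going by these compounds alone, the contrast with the directly attached aryl group now rests on two linked rings rather than one, as (pyridin-2-yl)methyl in place of 3-fluorophenyl also gives a lower number (an 8.0-fold lower number from compound 2 to compound 4 (0.90 log units; beyond the scatter)), although compound 2 remains the only directly attached example and differs in both its link and its fluorine.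

No measurement on hand explains any of these steps. Still open, on these data alone, are whether a longer chain such as 2-phenylethyl, the isomeric (pyridin-3-yl)methyl or (pyridin-4-yl)methyl groups, or an unsubstituted phenyl directly on the amide-type nitrogen would fit the same picture, and whether a carboxylic acid or an amine on the benzyl ring would be accepted.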